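The source may hold more compounds than are shown below. What is called first, only, known or untested is meant among the compounds shown, and "the series" means these compounds.

Measured compounds:
compound 1, `CC(Nc1nc(N)nc2ccc(-c3cnn(C4CCNCC4)c3)cc12)c1c(Cl)ccc(F)c1Cl`, 2230 nM
compound 2, `CC(Nc1nc(N)nc2ccc(-c3cnn(C)c3)cc12)c1c(Cl)ccc(F)c1Cl`, 2870 nM
compound 3, `c1cnc2ccc(Nc3ncnc4ccc(-c5cnn(C6CCNCC6)c5)cc34)cc2c1`, 61900 nM

All three were tested in a functional assay on MCF7 cells (Homo sapiens) for antiproliferative activity, read by MTT assay, with a stated time of 72 h; a lower number here means a stronger inhibitor, a higher number a weaker inhibitor. Compound 1 gives 2230 nM and compound 2 gives 2870 nM; the two differ by one change, (methyl in place of piperidin-4-yl on an aromatic nitrogen), and the step is a 1.3-fold higher number from compound 1 to compound 2 (0.11 log units; within the scatter). Compound 3, built on a different core, gives 61900 nM in this assay ; the difference between its core and the core of compound 1 is not broken down here, and compound 3 stands well apart from both compound 1 and compound 2.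

Compound 4, `Cn1cc(-c2ccc3ncnc(Nc4ccc5ncccc5c4)c3c2)cn1`, has not yet been measured. It differs from compound 3 by methyl in place of piperidin-4-yl on an aromatic nitrogen, the same change as between compound 1 and compound 2, made at a place described in the same words. Going by the values given here, because a 1.3-fold higher number from compound 1 to compound 2 (0.11 log units; within the scatter) was a small step, the same change on the core of compound 3 is expected to move the number little, although only one earlier example supports this and the core is different. For compound 4 the estimated value in this assay is 80000 nM, with a likely range from 25000 nM to 250000 nM. This expectation amounts to a step of a 1.3-fold higher number from compound 3 to compound 4 (0.11 log units; within the scatter). Compound 3 already gives 61900 nM, a weak number, and compound 4 is expected to remain in that weak region of the assay.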

Compound 4, half-maximal inhibitory concentration: 490 nM
For compound 4 the middle estimate is 160-fold (2.21 log units) above the measured one, outside the stated range (below it).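

In this assay, putting methyl in place of piperidin-4-yl on the aromatic nitrogen gives a 130-fold lower number from compound 3 to compound 4 (2.10 log units; beyond the scatter), so on this core the change matters a great deal. Set beside the earlier pair, the same change does not carry over in size from one core to the other: the same change on two cores in this assay, a 1.3-fold higher number (0.11 log units; within the scatter) from compound 1 to compound 2 and a 130-fold lower number (2.10 log units; beyond the scatter) from compound 3 to compound 4, 160-fold (2.21 log units) apart, beyond the scatter of two such steps. This shows that, in these two pairs, a small step on one core says little about the step on another, but it does not show which feature of the cores makes the difference, and two pairs cannot establish a rule for the whole series.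

As far as these compounds go, it remains open how other groups in this place would behave on the core of compound 3, for example an ethyl group, a longer chain ending in an amine, or a cyclohexyl ring, which is the ring of piperidin-4-yl without its nitrogen and would help separate the role of the ring from that of the nitrogen. It is also open whether a step of this size would appear on any further core, or whether the two cores shown here mark the ends of a wider range.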